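Free hydroxyl in place of propargyl on the oxime oxygen

The source may report more compounds than this note shows. Statements on the series, on what has been measured and on what is new or still open speak of the compounds shown alone.

Of the compounds shown here, three of the shared core carry a measured number so far. Compound 1 `C#CCO/N=C/c1c(-c2ccc(C)cc2)nc2c(C)cccn12` gives 20 mg/kg in a functional assay on the whole organism (strain NMRI) with Mus musculus as the target, with a stated time of 0.5 h; on this read-out lower numbers stand for an effect already at smaller amounts and higher numbers for an effect only at larger amounts of compound. Compound 2 `COc1ccc(Cn2cc(CO/N=C/c3c(-c4ccccc4)nc4c(C)cccn34)nn2)cc1` gives 40 mg/kg in this assay. Compound 3 `C#CCO/N=C/c1c(-c2ccc(C)cc2)nc2ccc(Br)cn12` gives 20 mg/kg in this assay, level with compound 1 at the digits printed; the value of compound 2 lies within the usual scatter of that of compound 3, so no order among the three can be read from these numbers.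

Compound 4 `Cc1ccc(-c2nc3ccc(Br)cn3c2/C=N/O)cc1` has not been measured. It differs from compound 3 by one change: hydrogen in place of propargyl on an oxygen. Cut one bond further out, the change reads propargyloxy to hydroxy. For the measured compounds named here, no measured pair in the set isolates this change, so its size is unknown here. The expectation is a modest step from compound 3 to compound 4, a 1.5-fold higher number from compound 3 to compound 4 (0.18 log units; within the scatter), towards a somewhat higher number, not clearly beyond the scatter. For compound 4 the estimate in this assay is 30 mg/kg, with a range from 10 mg/kg to 100 mg/kg.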

Compound 4, minimum effective dose: 20 mg/kg
Beside the measured number, compound 4's estimate is 1.5-fold (0.18 log units) above it, within the range that was stated.
By their numbers in this assay, from the lowest: compounds 1, 3, 4 and 2 (each within the scatter of the next).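

In this assay, for the compounds shown here, the step on the oxime oxygen reads no change at the digits printed from compound 3 to compound 4 (within the scatter), and this is the first measured pair to isolate a change at this place. In this pair, the propargyl group, with its triple bond, can give way to hydrogen without a shift in the minimum effective dose beyond the scatter. The free hydroxyl therefore remains as usable here as the propargyloxy group, although this rests on a single pair and does not extend to the other compounds. No supporting measurement accounts for this result.

As far as these compounds go, whether a longer chain or a chain ending in a carboxylic acid or an amine on the same oxygen would also leave the read-out level remains open. The pair also leaves open whether the same replacement holds on the core of compound 1.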